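The source may hold more compounds than are shown below. What is called first, only, known or untested is meant among the compounds shown, and "the series" means these compounds.

Compound 1 `Nc1ccc(-c2cc(=O)c3c(N)c(F)c(Cl)c(F)c3o2)cc1F` and compound 2 `CN(C)CCCC(=O)OCc1c(F)c(N)c2c(=O)cc(-c3ccc(N)c(F)c3)oc2c1F` share one core. In a functional assay on MCF7 cells (Homo sapiens) for cytotoxicity, read by neutral red uptake, with a stated time of 3 days (a lower number here means a stronger inhibitor, a higher number a weaker inhibitor), compound 1 gives 210 nM, while compound 2 gives 29 nM, the lower of the two numbers shown. For the measured compounds named here, that gap is the only measured step, a 7.2-fold lower number from compound 1 to compound 2 (0.86 log units; beyond the scatter). Compound 3 `CCCOCc1c(F)c(N)c2c(=O)cc(-c3ccc(N)c(F)c3)oc2c1F` differs from compound 2 by propyl in place of (3-(dimethylamino)propyl)carbonyl on an oxygen on a saturated carbon. No measured step covers this change; the one step shown only says that the ester-bearing group went with a lower number, so removing most of it is expected to push the number back upward, though the propoxymethyl remains. Compound 3 is expected near 80 nM, within 25 nM to 250 nM. That amounts to an expected step of a 2.8-fold higher number from compound 2 to compound 3 (0.44 log units; beyond the scatter).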

Compound 3, half-maximal inhibitory concentration: 1200 nM
For compound 3 the middle estimate is 15-fold (1.18 log units) below the measured one, outside the stated range (above it).
By their numbers in this assay, from the lowest: compound 2; then compound 1; then compound 3.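

Replacing (3-(dimethylamino)propyl)carbonyl with propyl on the oxygen gives a 41-fold higher number from compound 2 to compound 3 (1.62 log units; beyond the scatter) in this assay, so the lower number of compound 2 does not come with just any chain at this place. Propoxymethyl in place of chloro gives a 5.7-fold higher number from compound 1 to compound 3 (0.76 log units; beyond the scatter) and thus moves the number the opposite way from the ester-bearing group. Nothing available explains this difference. Still open, going by these compounds, is whether a dimethylamino group on a plain ether chain, or a simple butanoyl ester without any amine, would go with the lower number.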